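The compounds below may be only part of what the source reports. "The series", "measured", "known", "first", "only" and "open" are said of these compounds alone.

In a functional assay on HCT-116 cells (Homo sapiens) for inhibition, read by CCK-8 assay, with a stated time of 48 h (a higher number here means a weaker inhibitor, a lower number a stronger inhibitor), compound 1 `COc1cc(N(Cc2ccc(Br)cc2)C(=O)CSC(=S)N2CCN(C(=O)OC(C)(C)C)CC2)cc(OC)c1OC` gives 11400 nM and compound 2 `COc1ccc(CN(C(=O)CSC(=S)N2CCN(C(=O)OC(C)(C)C)CC2)c2cc(OC)c(OC)c(OC)c2)cc1Br` gives 9710 nM, so compound 2 stands within the scatter of compound 1. Compound 3 `COc1ccc(CN(C(=O)CSC(=S)N2CCN(C(=O)OC(C)(C)C)CC2)c2cc(OC)c(OC)c(OC)c2)cc1C` differs from compound 2 in one place: methyl in place of bromo on an aromatic carbon. Among the measured compounds shown here, no measured step makes this exchange of bromo for methyl. The nearest evidence is a 1.2-fold lower number from compound 1 to compound 2 (0.07 log units; within the scatter), where 3-bromo-4-methoxyphenyl replaces 4-bromophenyl, so no shift beyond the scatter is expected in this assay, in either direction. The expected step is a 1.0-fold higher number from compound 2 to compound 3 (0.01 log units; within the scatter). For compound 3 the estimated value is 10000 nM, with an expected range from 4500 nM to 22000 nM.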

Compound 3, half-maximal inhibitory concentration: > 20000 nM
Compound 3: only a limit was reported (the forecaster's own chance of this, stated with the estimate: 3%); at least 2.0-fold (0.30 log units) between middle value and limit.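

Compound 3 gives only a limit in this assay: the limit of > 20000 nM in this assay, at which 1 of the 3 values shown sits. Among the compounds shown here, at this aromatic carbon, ortho to a methoxy group, methyl in place of bromo is the first change here to go beyond the scatter, with an at least 2.0-fold higher number from compound 2 to compound 3 (0.31 log units; beyond the scatter), so the group at this position matters in this assay. The other comparison shows an at least 1.7-fold higher number from compound 1 to compound 3 (0.24 log units; that floor lies within the scatter), which alone settles nothing.

Going by these compounds, the full size of the rise stays open. So does whether chloro, an amine or a longer chain at this carbon would keep the number close to that of compound 2.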